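Compound 4: a trifluoromethyl group returns

A few compounds are considered here, and "the series" means these few. Any claim that something is new, unique, unknown or untested is made for them only; others in the source may bear on it.

In an ADME assay on HepG2 cells (Homo sapiens) for cytotoxicity (on this read-out higher numbers stand for lower toxicity in this test and lower numbers for higher toxicity in this test), compound 3 (`COc1cccc(N2CC(=O)N(c3cccc(SC)c3)C(C(=O)NC3CCCC3)C2)c1`) gives > 50000 nM, a limit of the assay and not a number. Compound 1 (`CSc1cccc(N2C(=O)CN(c3ccccc3)CC2C(=O)NC2CCCC2)c1`) gives > 50000 nM, also a limit. Compound 2 (`CSc1cccc(N2C(=O)CN(c3ccc(C(F)(F)F)cc3)CC2C(=O)NC2CCCC2)c1`) reads 10000 nM. The change to compound 4 (`CSc1cccc(N2C(=O)CN(c3cncc(C(F)(F)F)c3)CC2C(=O)NC2CCCC2)c1`) is 5-(trifluoromethyl)pyridin-3-yl in place of 3-methoxyphenyl on an amine nitrogen in a ring. Going by the values given here, two measured steps bear on it, both beyond the scatter: an at least 5.0-fold lower number from compound 1 to compound 2 (0.69 log units; beyond the scatter) on adding trifluoromethyl, and an at least 5.0-fold higher number from compound 2 to compound 3 (0.69 log units; beyond the scatter) on the exchange of 4-(trifluoromethyl)phenyl for 3-methoxyphenyl. The step that the two limits leave unreadable from compound 1 to compound 3 cannot be read. Among the compounds with values here, no measured compound carries 5-(trifluoromethyl)pyridin-3-yl. A modest move towards a lower number is expected, and the estimated step is an at least 2.7-fold lower number from compound 3 to compound 4 (0.44 log units; beyond the scatter). For compound 4 the estimate is 18000 nM, with an expected range of 6000 nM to 50000 nM.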

Compound 4, half-maximal cytotoxic concentration: > 50000 nM
Compound 4: a limit, no number; the forecaster's own chance of this, stated with the estimate: 25%; at least 2.7-fold (0.44 log units) between middle value and limit.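

In this assay the step is an at least 5.0-fold higher number from compound 2 to compound 4 (0.69 log units; beyond the scatter) with 5-(trifluoromethyl)pyridin-3-yl in place of 4-(trifluoromethyl)phenyl on the amine nitrogen in a ring. Going by these compounds alone, a trifluoromethyl group on this aromatic ring therefore does not by itself go with the lower number, and compound 2 stays the only compound here with a number. The steps from compound 1 and compound 3 to compound 4 cannot be read, because each pair ends in two limits: the limit of > 50000 nM in this assay, at which 3 of the 4 values shown sit.

The ring nitrogen and the place of the trifluoromethyl group change together, and the compounds shown do not separate them. From the compounds shown here alone, how an amine or a carboxylic acid on this aromatic ring would read in this assay also stays open.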